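A few compounds are considered here, and "the series" means these few. Any claim that something is new, unique, unknown or untested is made for them only; others in the source may bear on it.

Measured compounds in an assay on cells (Endothelial cell) for binding affinity to Endothelin-1 receptor (Sus scrofa); a lower number here means a stronger inhibitor, a higher number a weaker inhibitor:
- compound 1 `COc1cccc(Oc2c(NS(=O)(=O)c3ccc(C(C)(C)C)cc3)ncnc2OCCOCc2ccccc2)c1`: 170 nM
- compound 2 `COc1cccc(Oc2c(NS(=O)(=O)c3ccc(C(C)(C)C)cc3)ncnc2OCCOc2ncccn2)c1`: 1.9 nM
- compound 3 `CSc1cnc(OCCOc2ncnc(NS(=O)(=O)c3ccc(C(C)(C)C)cc3)c2-c2ccc(C(C)C)cc2)nc1`: 1.2 nM

Among the measured compounds shown here, the one step that differs in a single place, an 89-fold lower number from compound 1 to compound 2 (1.95 log units; beyond the scatter), concerns the group on the oxygen of the saturated carbon. Compound 3 and compound 2 give numbers within the usual scatter of each other; the number for compound 1 is far higher than that of compound 3.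

Compound 4 `CSc1cnc(OCCOc2ncnc(NS(=O)(=O)c3ccc(C(C)(C)C)cc3)c2-c2ccc(C)s2)nc1` differs from compound 3 by 5-methylthiophen-2-yl in place of 4-isopropylphenyl on an aromatic carbon. For the measured compounds named here, no measured step touches this position, so nothing speaks for a change beyond the scatter; the expectation is a step of about a 1.7-fold higher number from compound 3 to compound 4 (0.22 log units; within the scatter) in this assay. Compound 4 is therefore estimated at 2 nM, with a range from 0.6 nM to 7 nM.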

Compound 4, half-maximal inhibitory concentration: 0.16 nM
Compound 4: the middle estimate sits 13-fold (1.10 log units) above what was measured; measured number below the stated range.
By their numbers in this assay, from the lowest: compound 4; then compounds 3 and 2 (each within the scatter of the next); then compound 1.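

In this assay, the aromatic carbon ortho to the 2-((5-(methylsulfanyl)pyrimidin-2-yl)oxy)ethoxy group responds to the choice of group: 5-methylthiophen-2-yl in place of 4-isopropylphenyl gives a 7.5-fold lower number from compound 3 to compound 4 (0.88 log units; beyond the scatter) on this core. A six-membered carbon ring is therefore not needed here, and the entering group, with 6 heavy atoms against 9, loses nothing. Nothing measured here accounts for the step.

The step changes ring and substituent together, so their shares cannot be separated. Going by these compounds, whether plain thiophen-2-yl, 4-methylphenyl or 5-methylfuran-2-yl would behave alike remains open.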